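Ester-to-acid step in the writhing series

A few compounds are considered here, and "the series" means these few. Any claim that something is new, unique, unknown or untested is made for them only; others in the source may bear on it.

Two compounds of the series have so far been run in a functional assay on the whole organism for inhibition, with Mus musculus as the target, in the writhing test, with stated times of 30 min and 1 h, at a dose of 25 mg/kg by the intraperitoneal route; on this read-out lower numbers stand for less inhibition and higher numbers for more inhibition at the one dose given (going by the name of the read-out). Compound 1 `CCOC(=O)c1nn(-c2ccc(Cl)cc2)c(-c2ccc(OC)cc2OC)c1C` gives 40% in this assay, the higher of the two numbers recorded. Compound 2 `COc1ccc(C2=NN(C(=O)NS(=O)(=O)c3ccc(C)cc3)CC2C)c(OC)c1` gives 20% in this assay, a number lower than that of compound 1 by a gap beyond the usual scatter. Compound 2 differs from compound 1 in more than one place, so no single structural step can be read from that pair.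

Compound 3 `COc1ccc(-c2c(C)c(C(=O)O)nn2-c2ccc(Cl)cc2)c(OC)c1` is the next entry and has not been measured. Relative to compound 1 the change is hydrogen in place of ethyl on an oxygen next to a carbonyl group. Going by the values given here, no measured pair isolates this change, so its size is unknown from the data. The expected step in this assay is small, not clearly beyond the scatter, leaning slightly toward more inhibition: a number 5 percentage points higher from compound 1 to compound 3 (within the scatter). For compound 3 the estimated value in this assay is 45%, within 20% to 70%.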

Compound 3, a percentage reported as inhibition, in the whole organism at one dose (the size of the read-out at that dose, not a potency): 40%
Compound 3: middle estimate off by 5 percentage points, on the high side, within the range that was stated.
By their numbers in this assay, from the lowest: compound 2; then compounds 1 and 3 (each within the scatter of the next).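

Hydrogen in place of ethyl on an oxygen next to a carbonyl group is the first change in the series that can be read on its own: in this assay the step is no change at the digits printed from compound 1 to compound 3 (within the scatter) for this single change. At this position and at the one dose given, the read-out therefore does not separate ethoxycarbonyl from carboxy, something the earlier pair, differing in more than one place, could not show. Nothing at hand bears on the reason for this result.

Open, on these data alone, is whether a longer chain such as butyl on this oxygen, or an amine in place of the ethoxy, would also stay within the scatter of compound 1 in this assay at this dose. Also open, as far as these compounds go, is whether ethoxy to hydroxy stays without effect at other doses, as the read-out gives a size at one dose and not a potency.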